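This account rests on a few compounds, and the source may have more. Where it says the series, first, only, none or still open, it means among the compounds named here.

Compound 1 `Cc1ccnc2nc(-c3ccc(F)cc3)cc(O)c12`: 51300 nM
Compound 2 `COc1cccc(-c2cc(O)c3c(C)ccnc3n2)c1`: 26.3 nM
Compound 3 `Cc1cnc2nc(-c3ccc(Cl)cc3)cc(O)c2c1`: 1150 nM

In a functional assay on PC-3 cells (Homo sapiens) (on this read-out higher numbers stand for weaker inhibition of growth and lower numbers for stronger inhibition of growth), compound 3 gives 1150 nM, which is the second highest of the three numbers. Compound 2 gives 26.3 nM, the nearest neighbour and a lower number, with a gap that lies beyond the scatter. Compound 1 gives 51300 nM, the furthest of the three and a higher number, again beyond the scatter. Compound 3 therefore sits between the two. Both gaps lie beyond the scatter.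

The step from compound 3 to compound 4 `COc1ccc(-c2cc(O)c3cc(C)cnc3n2)cc1` is a single change: methoxy in place of chloro on an aromatic carbon. The site is on an aromatic carbon of a six-membered aromatic ring of carbon only, para to a large group. Within the data shown here, no measured pair in this set shows this change on its own, so its size is not known from the data. Compound 2, which carries a methoxy group, gives the lowest number at 26.3 nM, but it also differs in its core, so that value is only a hint.

On that basis, compound 4 is expected to give a lower number than compound 3, with the step of a 2.9-fold lower number from compound 3 to compound 4 (0.46 log units; beyond the scatter) reaching beyond the scatter. The estimate for compound 4 in this assay is 400 nM, within a range from 80 nM to 2000 nM.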

Compound 4, concentration for 50% growth inhibition: 5370 nM
Beside the measured number, compound 4's estimate is 13-fold (1.13 log units) below it, outside the stated range (above it).
By their numbers in this assay, from the lowest: compound 2; then compound 3; then compound 4; then compound 1.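

In this assay, among these compounds, the reading a 4.7-fold higher number from compound 3 to compound 4 (0.67 log units; beyond the scatter) is the first direct look at this change, and it ties methoxy in place of chloro on an aromatic carbon, para to a large group, to weaker inhibition of growth rather than stronger. Among the compounds shown here, it also shows that this site responds to the swap by more than the scatter, which the earlier compounds could not show: none of them formed a pair differing in one place, and compound 2, though it too carries a methoxy group, differs from compound 4 in more than one place, so steps involving it cannot be read. Nothing measured here accounts for the direction or the size of this step.

The compounds shown leave open how other groups at this site would compare with chloro and methoxy, for example an amine, a hydroxyl or a longer chain such as ethoxy. They also leave open whether the same exchange would move the number in the same direction on the core of compound 1 or of compound 2, as this single pair speaks only for the core of compound 3.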